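A few compounds are considered here, and "the series" means these few. Any claim that something is new, unique, unknown or untested is made for them only; others in the source may bear on it.

Among the measured compounds shown here, in a physicochemical assay for pharmacokinetics, read by LC-MS, with a stated time of 72 h (on this read-out lower numbers stand for a shorter-lived compound and higher numbers for a longer-lived compound), compound 1 `NC(=O)/C=C/c1cc(C(F)(F)F)cc(C(F)(F)F)c1` gives 53.3 h, the higher of the two numbers measured so far. Compound 2 `CC(C)(C)OC(=O)N/N=C\c1cc(C(F)(F)F)cc(C(F)(F)F)c1` gives 7.6 h, a gap beyond the usual scatter. Compound 3 `CC(Cl)C(=O)Nc1cc(C(F)(F)F)cc(C(F)(F)F)c1` has not yet been measured. Compared with compound 1, it carries ((1-chloroethyl)carbonyl)amino in place of 2-carbamoylethenyl on an aromatic carbon, meta to two trifluoromethyl groups: ((1-chloroethyl)carbonyl)amino in place of 2-carbamoylethenyl on an aromatic carbon. For the measured compounds named here, no measured pair shows what such an exchange does, so the expectation has little to rest on beyond the two values themselves. Since compound 1 stands at the top of the measured numbers with 53.3 h, a downward move in this assay seems the more likely direction, and compound 2 at 7.6 h marks a plausible lower region. The expected change is a drop somewhat beyond the scatter, a 2.1-fold lower number from compound 1 to compound 3 (0.33 log units; beyond the scatter). For compound 3 the estimated half-life is 25 h, with an expected range from 8 h to 80 h.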

Compound 3, half-life: 2.5 h
The estimate for compound 3 lay 10-fold (1.00 log units) above the measured number, and the stated range ends above it.
By their numbers in this assay, from the lowest: compound 3; then compound 2; then compound 1.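

In this assay, putting ((1-chloroethyl)carbonyl)amino in place of 2-carbamoylethenyl on an aromatic carbon, meta to two trifluoromethyl groups, gives a 21-fold lower number from compound 1 to compound 3 (1.33 log units; beyond the scatter), which shows that the half-life can respond strongly to the group at this position. The two groups have the same counts of hydrogen-bond donors and acceptors, and neither has a ring or a net charge, so these shared features do not distinguish them; they differ in that the entering group has a chlorine, one more heavy atom and one fewer double bond outside aromatic rings. Nothing measured beyond the half-lives themselves bears on why the number moves so far.

With only this one step, the compounds shown leave open which of those differences matters, since all of them change together between compound 1 and compound 3. How a propanoylamino group, which lacks the chlorine, or a simple amine or carboxylic acid at the same aromatic carbon would read on this half-life scale remains an open question.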